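The source may report more compounds than this note shows. Statements on the series, on what has been measured and on what is new or still open speak of the compounds shown alone.

Working notes on the series. In an ADME assay on HEK293 cells (Homo sapiens) for antiproliferative activity, read by MTT assay, with a stated time of 24 h (on this read-out lower numbers stand for stronger inhibition and higher numbers for weaker inhibition), compound 1 `COc1cc(C(=O)/C=C/c2cc(-c3cc(OC)c(OC)c(OC)c3)n3nc(-c4ccccc4)cc3n2)cc(OC)c1OC` gives only a limit, >= 100000 nM (the limit of >= 100000 nM in this assay, at which 1 of the 3 values shown sits). Compound 2 `COc1ccc(-c2cc(/C=C/C(=O)c3cc(OC)c(OC)c(OC)c3)nc3cc(-c4ccccc4)nn23)cc1OC` gives 35000 nM in this assay, and compound 3 `COc1cc(-c2cc(C(=O)/C=C/c3ccccc3)nc3cc(-c4ccccc4)nn23)cc(OC)c1OC` gives 44800 nM, a number that sits within the scatter of compound 2, so the two are not separated. Compound 4 `COc1ccc(C(=O)/C=C/c2cc(-c3ccc(OC)c(OC)c3)n3nc(-c4ccccc4)cc3n2)cc1OC` carries the change (hydrogen in place of methoxy on an aromatic carbon). Going by the values given here, the one measured step of this kind, an at least 2.8-fold lower number from compound 1 to compound 2 (0.45 log units; beyond the scatter), removed a methoxy at a different place in the molecule, so it bears only loosely on the present change. A step of the same direction, though likely smaller, is expected, and compound 4 is estimated at 20000 nM (range 8000 nM to 50000 nM), the expected step being a 1.8-fold lower number from compound 2 to compound 4 (0.24 log units; within the scatter).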

Compound 4, half-maximal inhibitory concentration: 32500 nM
Beside the measured number, compound 4's estimate is 1.6-fold (0.21 log units) below it, and the stated range covers the measured number.
By their numbers in this assay, from the lowest: compounds 4, 2 and 3 (each within the scatter of the next). At a limit, above all of these: compound 1.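

In this assay, going from 3,4,5-trimethoxyphenyl to 3,4-dimethoxyphenyl at this position gives a 1.1-fold lower number from compound 2 to compound 4 (0.03 log units; within the scatter), so hydrogen in place of methoxy here leaves the number unresolved from that of its parent. The same kind of change at the other place gave an at least 2.8-fold lower number from compound 1 to compound 2 (0.45 log units; beyond the scatter), so its size does not carry over to this position. That earlier step starts from a limit: the limit of >= 100000 nM in this assay, at which 1 of the 4 values shown sits.

Open, from the compounds shown here alone, is whether an amine or a carboxylic acid at this position would move the number beyond the scatter. Also open, going by these compounds, is whether losing the remaining methoxy groups of this ring would do so.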